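An Aromatic Ring Replaces a Methyl on the Core

This account rests on a few compounds, and the source may have more. Where it says the series, first, only, none or still open, it means among the compounds named here.

Compound 1 `Cc1cc2[nH]nc(N)c2c(=O)[nH]1` gives -1% in an assay on isolated protein for inhibition of serine/threonine-protein kinase D2 (Homo sapiens), read by mobility shift assay, tested at 30 uM; a lower number here means less inhibition, a higher number more inhibition at the concentration tested (going by the name of the read-out).
Compound 2 `Nc1n[nH]c2cc(-c3ccncc3)[nH]c(=O)c12` gives 29% in this assay.

Compound 1 stands lowest of the two measured numbers; compound 2 lies higher by a gap beyond the scatter. Compound 3 `Nc1n[nH]c2cc(-c3cccs3)[nH]c(=O)c12` carries the change (thiophen-2-yl in place of methyl on an aromatic carbon). Among the measured compounds shown here, no step between measured compounds is known for this change, but compound 2 with its 29% shows a ring in this place going with more inhibition, so a rise beyond the scatter is expected. In this assay the step is expected to be a number 21 percentage points higher from compound 1 to compound 3 (beyond the scatter). Compound 3 is estimated at 20%, with a range from 2% to 42%.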

Compound 3, a percentage reported as inhibition, at one concentration (the size of the read-out at that concentration, not a potency): 5%
For compound 3 the middle estimate is 15 percentage points above the measured one; the range from low to high includes it.
By their numbers in this assay, from the lowest: compounds 1 and 3 (each within the scatter of the next); then compound 2.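

Thiophen-2-yl in place of methyl on this aromatic carbon gives a number 6 percentage points higher from compound 1 to compound 3 (within the scatter) in this assay and so does not move the number beyond the scatter. An aromatic ring here therefore does not by itself go with more inhibition: compound 3 gives 5% while compound 2, with a different ring here, gives 29% in the same test. Nothing measured on these compounds accounts for this result.

Going by these compounds, whether an amine, a carboxylic acid or a longer alkyl chain at this place would change the number remains open, as does the effect of a change elsewhere on the shared core.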